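Shortening the amino acid side chain on a purine glycinamide

A few compounds are considered here, and "the series" means these few. Any claim that something is new, unique, unknown or untested is made for them only; others in the source may bear on it.

Compound 1 `O=C(O)[C@@H]1CCCN1C(=O)CN(c1nc(Cl)nc2[nH]cnc12)C1CC1`: 26%
Compound 2 `N=C(N)NCCC[C@H](NC(=O)CN(c1nc(Cl)nc2[nH]cnc12)C1CC1)C(=O)O`: 27.6%
Compound 3 `O=C(CN(c1nc(Cl)nc2[nH]cnc12)C1CC1)N[C@@H](CO)C(=O)O`: 43.9%

In a functional assay on the whole organism (Tail, strain ICR) with Mus musculus as the target, in the tail flick test, with a stated time of 90 min, at a dose of 25 umol/kg by the oral route (a lower number here means a weaker effect, a higher number a stronger effect of the compound at the dose given), compound 3 gives the highest of the three numbers; its margin over compound 2 and over compound 1 lies beyond the scatter, so it is the most active of the measured set. Compound 4 `O=C(O)CNC(=O)CN(c1nc(Cl)nc2[nH]cnc12)C1CC1` differs from it by hydrogen in place of hydroxymethyl on a saturated chain carbon bound to an amide-type nitrogen and a carbonyl carbon.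

Among the measured compounds shown here, two measured steps touch the same carbon or the same amide-bound group. The step of a number 16.3 percentage points higher from compound 2 to compound 3 (beyond the scatter) exchanged a large side chain for a small one on that carbon and raised the read-out, and the step of a number 17.9 percentage points higher from compound 1 to compound 3 (beyond the scatter) opened the cyclic amide into the hydroxymethyl-bearing chain with a similar gain. For the measured compounds named here, both gains arrived with the hydroxymethyl arm, and compound 4 gives that arm up, so a modest fall in this assay is expected rather than a further rise; no measured pair shows what removing the side chain entirely does.

Compound 4 is therefore estimated at 34%, within 20% to 48%, an expected step of a number 9.9 percentage points lower from compound 3 to compound 4 (within the scatter).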

Compound 4, a percentage reported as activity, at one dose (the size of the read-out at that dose, not a potency): 32.3%
Compound 4: middle estimate off by 1.7 percentage points, on the high side; the range from low to high includes it.
By their numbers in this assay, from the lowest: compounds 1, 2 and 4 (each within the scatter of the next); then compound 3.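

In this assay, hydrogen in place of hydroxymethyl on this saturated chain carbon gives a clear loss (a number 11.6 percentage points lower from compound 3 to compound 4 (beyond the scatter)), so the higher read-out of compound 3 goes with the hydroxymethyl group and not simply with a small side chain. Removing the larger side chain outright brings no gain beyond the scatter (a number 4.7 percentage points higher from compound 2 to compound 4 (within the scatter)), and neither does replacing 2-carboxypyrrolidin-1-yl with (carboxymethyl)amino (a number 6.3 percentage points higher from compound 1 to compound 4 (within the scatter)), so compound 4 cannot be told apart from compound 2 or compound 1. No evidence at hand accounts for the effect of the hydroxymethyl group.

Going by these compounds, it remains open whether a methyl group or a primary amine on this carbon would match hydroxymethyl. Also open, on these data alone, is whether a longer chain ending in a hydroxyl group would hold the read-out of compound 3.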